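Methyl for methoxy on the aryl of compound 1

The source may hold more compounds than are shown below. What is called first, only, known or untested is meant among the compounds shown, and "the series" means these compounds.

Compound 1 `COc1ccc(C(C)NC(=O)/N=C(\N)NCCCc2sc(N)nc2C)cc1` was examined in a functional assay on Right cardiac atrium for agonist activity at histamine H2 receptor (Cavia porcellus), with a stated time of 30 min, in the presence of a further agent that is not named here (on this read-out higher numbers stand for an effect only at larger amounts of compound and lower numbers for an effect already at smaller amounts), where compound 1 gives 38 nM. Among the measured compounds shown here, the only other measured compound, compound 2 `Cc1nc(N)sc1CCCN/C(N)=N/C(=O)NC(c1ccccc1)c1ccccc1`, gives 39.8 nM in this assay, so the two values lie within the scatter of each other and neither can be called the more potent. Compound 3 `Cc1ccc(C(C)NC(=O)/N=C(\N)NCCCc2sc(N)nc2C)cc1` has not been measured. It differs from compound 1 by methyl in place of methoxy on an aromatic carbon, which, read one bond further out, is 4-methoxyphenyl to 4-methylphenyl. For the measured compounds named here, no measured pair shows this change, so nothing among the measured compounds tells its size. Because compound 1 gives 38 nM and compound 2 gives 39.8 nM with quite different groups on the same side of the shared core, the step from compound 1 to compound 3 is expected to be small, a 1.2-fold higher number from compound 1 to compound 3 (0.07 log units; within the scatter), with no direction beyond the scatter. Compound 3 is therefore estimated at 45 nM in this assay, within 15 nM to 140 nM.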

Compound 3, half-maximal effective concentration: 22.4 nM
Estimate against measurement, compound 3: 2.0-fold (0.30 log units) above, within the range that was stated.
By their numbers in this assay, from the lowest: compounds 3, 1 and 2 (each within the scatter of the next).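

In this assay, among the compounds shown here, replacing methoxy with methyl gives a 1.7-fold lower number from compound 1 to compound 3 (0.23 log units; within the scatter), the first direct reading of this change on an aromatic carbon para to a large group. The methoxy takes one hydrogen-bond acceptor with it and the methyl brings none, yet the step stays inside the usual variation, so this acceptor is not shown to be needed for agonist activity at this position. No measurement here offers an explanation for the size of this step.

Still open, going by these compounds, is whether a different group at this position, such as an amine, a carboxylic acid or a longer alkyl chain, would shift the number beyond the scatter. The compounds shown also leave open whether methyl or methoxy on another carbon of the same ring would read any differently.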